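The compounds below may be only part of what the source reports. "The series", "measured", "known", "first", "only" and "open" are said of these compounds alone.

The series shares one core; compound 1 `Nc1cc(N)c2nc(-c3ccccc3)c(NCc3ccc(Cl)c(Cl)c3)nc2c1` carries a 3,4-dichlorophenyl on the saturated chain carbon bound to the ring nitrogen, and in a functional assay on SK-MEL-28 cells (Homo sapiens) for inhibition, read by sulforhodamine B assay, with a stated time of 48 h (on this read-out lower numbers stand for stronger inhibition of growth and higher numbers for weaker inhibition of growth), compound 1 gives 18600 nM. Compound 2 `COc1ccc(CNc2nc3cc(N)cc(N)c3nc2-c2ccccc2)cc1OC` carries 3,4-dimethoxyphenyl at that place, and in this assay compound 2 gives 13500 nM. The step of a 1.4-fold lower number from compound 1 to compound 2 (0.14 log units; within the scatter) shows that swapping the two halogens for two methoxy groups changed nothing that the assay can resolve. Compound 3 `CCOC(=O)[C@H](CCC(=O)O)NC(=O)c1ccc(Sc2nc3cc(N)cc(N)c3nc2-c2ccccc2)cc1`, with a different attachment to the core, gives 6760 nM in this assay. On the three numbers shown, compound 2 sits within the scatter of both compound 1 and compound 3, so no ranking among them is supported.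

Compound 4 `COc1cc(CNc2nc3cc(N)cc(N)c3nc2-c2ccccc2)cc(OC)c1OC` differs from compound 2 by methoxy in place of hydrogen on an aromatic carbon. Going by the values given here, the only measured step that bears on it is the one from compound 1 to compound 2, a change of substituents on the same benzyl ring, and it stayed within the scatter. A third methoxy on that ring is therefore expected to leave this assay essentially unchanged, with no step beyond the scatter in either direction. For compound 4 the estimated value is 13000 nM, with a range of 6000 nM to 30000 nM, an expected step of a 1.0-fold lower number from compound 2 to compound 4 (0.02 log units; within the scatter).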

Compound 4, concentration for 50% growth inhibition: 8510 nM
Compound 4: middle estimate off by 1.5-fold (0.18 log units), on the high side; the range from low to high includes it.
By their numbers in this assay, from the lowest: compounds 3, 4, 2 and 1 (each within the scatter of the next, the first and the last beyond it).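

In this assay the added methoxy, ortho to a methoxy group and meta to a large group, gives a step (a 1.6-fold lower number from compound 2 to compound 4 (0.20 log units; within the scatter)) that the assay cannot resolve, so this aromatic carbon accepts a further methoxy without a measurable effect on growth inhibition. Taken with the earlier exchange of the two halogens for two methoxy groups (a 1.4-fold lower number from compound 1 to compound 2 (0.14 log units; within the scatter)), this makes two separate changes on the same benzyl ring, one replacing substituents and one adding a substituent, and both stay within the scatter. No accompanying measurement bears on this result, so the flat response remains a plain observation.

Going by these compounds alone, still open is whether a different group at this aromatic carbon, such as an amine, a carboxylic acid or a longer chain, would produce a step beyond the scatter, since the only group entering here is methoxy. Within the data shown here, also open is what the attachment to the shared core contributes, as compound 3 differs from the other compounds in more than one place and offers no single-change step to read.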